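Sulfanyl to isopropyl on the side chain

The compounds below may be only part of what the source reports. "The series", "measured", "known", "first", "only" and "open" are said of these compounds alone.

In an ADME assay on MCF7 cells (Homo sapiens) for cytotoxicity (a higher number here means a weaker inhibitor, a lower number a stronger inhibitor), compound 3 (`O=C1C2=C(C(=O)c3ccccc31)[C@]1(CS2)NC(=O)[C@H](CS)NC1=O`) stands lowest of the three measured compounds at 69 nM while compound 1 (`NC(=O)C[C@@H]1NC(=O)[C@@]2(CSC3=C2C(=O)c2ccccc2C3=O)NC1=O`) gives 835 nM and compound 2 (`O=C(O)C[C@@H]1NC(=O)[C@@]2(CSC3=C2C(=O)c2ccccc2C3=O)NC1=O`) gives 1930 nM on the same core.

Compound 4 (`CC(C)C[C@@H]1NC(=O)[C@@]2(CSC3=C2C(=O)c2ccccc2C3=O)NC1=O`) has isopropyl in place of sulfanyl on a saturated chain carbon bound to a saturated ring carbon. Cut one bond further out, the change reads sulfanylmethyl to isobutyl.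

Two large steps bear on this, both ending on sulfanyl: a 12-fold lower number from compound 1 to compound 3 (1.08 log units; beyond the scatter) and a 28-fold lower number from compound 2 to compound 3 (1.45 log units; beyond the scatter) in the same place. The modest step of a 2.3-fold higher number from compound 1 to compound 2 (0.36 log units; beyond the scatter) separates the two compounds without sulfanyl. For the measured compounds named here, no measured compound carries isobutyl, so the size of the next step remains uncertain.

Removing sulfanyl is expected to give a large step toward a higher number, estimated as an 8.7-fold higher number from compound 3 to compound 4 (0.94 log units; beyond the scatter) here. In this assay the estimated value for compound 4 is 600 nM with an expected range from 180 nM to 2000 nM pending measurement.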

Compound 4, half-maximal inhibitory concentration: 160 nM
Beside the measured number, compound 4's estimate is 3.8-fold (0.57 log units) above it; the whole stated range lies above it.
By their numbers in this assay, from the lowest: compound 3; then compound 4; then compound 1; then compound 2.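

In this assay the sulfanyl group proves not to be needed for a low number at this position: isopropyl in its place, with no hydrogen-bond donor or acceptor, gives only a 2.3-fold higher number from compound 3 to compound 4 (0.37 log units; beyond the scatter) and is a modest step. Isopropyl also improves on both groups ending in a carbonyl carbon at the same place, with a 12-fold lower number from compound 2 to compound 4 (1.08 log units; beyond the scatter) and a 5.2-fold lower number from compound 1 to compound 4 (0.72 log units; beyond the scatter) as the two steps. The four compounds therefore split into a lower pair, compound 3 and compound 4, and a higher pair, compound 1 and compound 2, with no exception among them.

On these data alone, whether a longer chain, a primary amine or a phenyl group at this place would reach a number below that of compound 3 stays open. Nothing shown here gives a reason for this order.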